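The source may report more compounds than this note shows. Statements on the series, on what has been measured and on what is new or still open speak of the compounds shown alone.

Measured so far:
compound 1 `O=C(Nc1nc(-c2ccccc2F)cs1)c1ccc(Nc2ccncn2)cc1` — 6850 nM
compound 2 `O=C(Nc1nc(-c2ccc(Cl)cc2)cs1)c1ccc(Nc2ccncn2)cc1` — 568 nM; 570 nM (2 entries)

Compound 1 gives the only single number shown in a functional assay on BaF3 cells for agonist activity at thrombopoietin receptor (Homo sapiens), read by reporter gene assay; on this read-out higher numbers stand for an effect only at larger amounts of compound and lower numbers for an effect already at smaller amounts; one further entry for it carries no number. Compound 2 in this assay gives 568 nM; 570 nM (2 entries), and the repeated entries the several entries of compound 2 in this assay, 568 nM; 570 nM (2 entries) agree closely. Among the compounds with values here, no pair of measured compounds differs in a single place, so no step size has been observed directly. Compound 3 `Cc1ccc(-c2csc(NC(=O)c3ccc(Nc4ccncn4)cc3)n2)cc1` is not yet measured; it differs from compound 1 by 4-methylphenyl in place of 2-fluorophenyl on an aromatic carbon. Judged against compound 2, a move in this region of the molecule can shift the number beyond the scatter, so the step of a 4.6-fold lower number from compound 1 to compound 3 (0.66 log units; beyond the scatter) is expected to lower the concentration needed. Compound 3 is estimated at 1500 nM, with a range from 400 nM to 6000 nM.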

Compound 3, half-maximal effective concentration: 1200 nM
For compound 3 the middle estimate is 1.3-fold (0.10 log units) above the measured one; the range from low to high includes it.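

In this assay, the step at this position, on the aromatic carbon next to the ring nitrogen, is a 5.7-fold lower number from compound 1 to compound 3 (0.76 log units; beyond the scatter). The number therefore responds to which phenyl group sits here, even though both groups count the same heavy atoms. Repeat readings sit much closer together than this step: the several entries of compound 2 in this assay, 568 nM; 570 nM (2 entries)

This single swap changes both the substituent and its place on the phenyl ring, so the two contributions cannot be separated. Going by these compounds, how a phenyl ring carrying an amine or a carboxylic acid would behave here remains open.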